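This account rests on a few compounds, and the source may have more. Where it says the series, first, only, none or still open, it means among the compounds named here.

In a functional assay on HCT-116 cells (Homo sapiens) for inhibition, read by MTT assay, with a stated time of 72 h (on this read-out lower numbers stand for stronger inhibition of growth and higher numbers for weaker inhibition of growth), compound 1 `NNC(=O)CCc1ccncc1-c1ccc2ccccc2c1` gives > 30000 nM, which is a limit of the assay and not a number. This is the limit of > 30000 nM in this assay, at which 1 of the 3 values shown sits. Compound 2 `O=C(O)COc1ccncc1-c1ccc2ccccc2c1` offers no help, since in this assay compound 2 stands as "not determined" (no result reported). Compound 3 `CCOC(=O)/C=C/c1ccncc1-c1ccc2ccccc2c1` gives 910 nM.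

Compound 4 `O=C(CCc1ccncc1-c1ccc2ccccc2c1)N1CCOCC1` changes compound 1 at the end of its side chain: morpholin-4-yl in place of aminoamino on a carbonyl carbon. Morpholin-4-yl takes the place of aminoamino on a carbonyl carbon, and the rest of the molecule stays the same.

Among the compounds with values here, only one measured step bears on this change: an at least 32-fold lower number from compound 1 to compound 3 (1.51 log units; beyond the scatter). It is large and beyond the scatter, but it replaces the whole 2-(aminocarbamoyl)ethyl group with 2-(ethoxycarbonyl)ethenyl, so it is only a loose guide. It does show that the number can move when this part of compound 1 is altered.

A much smaller move towards lower numbers is therefore expected, and the reading may well stay at the limit. The expected step is an at least 2.5-fold lower number from compound 1 to compound 4 (0.39 log units; beyond the scatter). The estimate for compound 4 is 12000 nM, with an expected range from 3000 nM to 40000 nM.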

Compound 4, concentration for 50% growth inhibition: > 30000 nM
Compound 4: a limit, no number (the forecaster's own chance of this, stated with the estimate: 40%); at least 2.5-fold (0.39 log units) between middle value and limit.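

In this assay compound 4 gives > 30000 nM, which is a limit of the assay and not a number. Compound 1 sits at the same limit, so no step between compound 1 and compound 4 can be read: the limit of > 30000 nM in this assay, at which 2 of the 4 values shown sit.

The compounds shown leave open whether morpholin-4-yl in place of aminoamino on a carbonyl carbon changes inhibition of growth at all.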